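The compounds below may be only part of what the source reports. "The series", "measured", "known", "first", "only" and "open" are said of these compounds alone.

Three compounds have been measured in a functional assay on A549 cells (Homo sapiens) for antiproliferative activity, read by MTT assay, with a stated time of 48 h; on this read-out higher numbers stand for weaker inhibition of growth and lower numbers for stronger inhibition of growth:

compound 1 `CCOc1cc(NC(=O)CCCCCCC(=O)Nc2ccccc2N)cc2c1OCC([N+](=O)[O-])=C2` gives 11700 nM
compound 2 `CCOc1cc(NC(=O)CCCCCCC(=O)Nc2cc(-c3ccc(C)s3)ccc2N)cc2c1OCC([N+](=O)[O-])=C2` gives 5830 nM
compound 3 `CCOc1cc(NC(=O)CCCCCC(=O)Nc2cc(-c3ccc(C)s3)ccc2N)cc2c1OCC([N+](=O)[O-])=C2` gives 5070 nM

Compound 4 `CCOc1cc(NC(=O)CCCCCC(=O)Nc2ccccc2N)cc2c1OCC([N+](=O)[O-])=C2` has not yet been measured. It is made from compound 3 by one change, (hydrogen in place of 5-methylthiophen-2-yl on an aromatic carbon). The same change, (hydrogen in place of 5-methylthiophen-2-yl on an aromatic carbon), links compound 2 to compound 1, and its two place descriptions match word for word, so it is the same change on a different core; the difference between the cores of compound 2 and compound 3 is not broken down here. For that earlier pair the measured step was a 2.0-fold higher number from compound 2 to compound 1 (0.30 log units; within the scatter). The step from compound 3 to compound 4 is expected to be of similar size, a 2.1-fold higher number from compound 3 to compound 4 (0.32 log units; beyond the scatter), because the earlier pair gave a 2.0-fold higher number from compound 2 to compound 1 (0.30 log units; within the scatter) and because compound 3 starts from 5070 nM. Compound 4 is therefore estimated at 10500 nM, with a likely range from 5000 nM to 22000 nM.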

Compound 4, concentration for 50% growth inhibition: 12200 nM
Estimate against measurement, compound 4: 1.2-fold (0.07 log units) below; low and high end bracket the measured number.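

In this assay, putting hydrogen in place of 5-methylthiophen-2-yl gives a 2.4-fold higher number from compound 3 to compound 4 (0.38 log units; beyond the scatter), and this step agrees with the one seen on the other core: the same change on two cores in this assay, a 2.0-fold higher number (0.30 log units; within the scatter) from compound 2 to compound 1 and a 2.4-fold higher number (0.38 log units; beyond the scatter) from compound 3 to compound 4, 1.2-fold (0.08 log units) apart, within the scatter of two such steps. The change therefore carries over between these two cores at much the same modest size, while the two compounds without the 5-methylthiophen-2-yl group, which differ only along the chain, show a 1.0-fold higher number from compound 1 to compound 4 (0.02 log units; within the scatter). This rests on just two closely related cores, however, so it does not show that the change would behave alike on a more different core, nor why the step arises.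

Going by these compounds, it remains open how a phenyl ring or a chlorine atom in the same place would compare. A longer chain also remains untested among the compounds shown here.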